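A few compounds are considered here, and "the series" means these few. Any claim that something is new, unique, unknown or untested is made for them only; others in the source may bear on it.

Of the compounds shown here, three that share one core have been measured in an assay on cells for activation of probable G-protein coupled receptor 34 (Mus musculus), with a stated time of 1 h; a higher number here means a larger maximal response, a lower number a smaller maximal response. Compound 1 `Cc1ccccc1Oc1cccc(COc2ccccc2CCC(=O)OCCCOP(=O)(O)OC[C@H](N)C(=O)O)c1` gives 0.28. Compound 2 `N[C@@H](COP(=O)(O)OCCCOC(=O)CCc1ccccc1OCc1cccc(Oc2ccc(Br)cc2)c1)C(=O)O` gives 0.97. Compound 3 `CCc1ccc(Oc2cccc(COc3ccccc3CCC(=O)OCCCOP(=O)(O)OC[C@H](N)C(=O)O)c2)cc1` gives 0.42, the second highest of the three: the step a number 0.14 higher from compound 1 to compound 3 (beyond the scatter) is modest, while the step a number 0.55 lower from compound 2 to compound 3 (beyond the scatter) is large, and the step a number 0.69 higher from compound 1 to compound 2 (beyond the scatter) is large as well.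

Compound 4 `CC(C)(C)c1ccc(Oc2cccc(COc3ccccc3CCC(=O)OCCCOP(=O)(O)OC[C@H](N)C(=O)O)c2)cc1` differs from compound 3 in one place: tert-butyl in place of ethyl on an aromatic carbon. Within the data shown here, no measured step exchanges one alkyl group for another on that ring. The steps that touch the same carbon are a number 0.55 lower from compound 2 to compound 3 (beyond the scatter), a large loss when ethyl replaces bromo, and a number 0.14 higher from compound 1 to compound 3 (beyond the scatter), a modest gain when the ring bearing ethyl replaces the ring bearing methyl. Neither tells how a larger alkyl group behaves there, so the expected step a number 0.080 higher from compound 3 to compound 4 (within the scatter) is small, upward at most by a modest amount, and may lie within the scatter. Compound 4 is therefore expected to give about 0.5 in this assay, with a range from 0.25 to 0.8.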

Compound 4, intrinsic activity: the largest response reached, as a fraction of the reference agonist's: 0.079
Compound 4: the middle estimate sits 0.42 above what was measured, and the stated range ends above it.
By their numbers in this assay, from the lowest: compound 4; then compound 1; then compound 3; then compound 2.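

Among these compounds, at this aromatic carbon, a larger alkyl group lowers the maximal response in this assay rather than preserving or raising it: exchanging ethyl for tert-butyl gives a number 0.34 lower from compound 3 to compound 4 (beyond the scatter), a large loss that the earlier compounds could not reveal. The tert-butyl compound also lies far from the bromo compound, at a number 0.89 lower from compound 2 to compound 4 (beyond the scatter), and falls short of the 2-methylphenyl compound, at a number 0.20 lower from compound 1 to compound 4 (beyond the scatter), which makes compound 4 the lowest of the four. Nothing measured here accounts for this drop.

Going by these compounds, it remains open whether the loss follows the number of carbons or the branching, which isopropyl or n-butyl on the same carbon could separate. Whether chloro or methoxy there would approach the response of the bromo compound is also unresolved.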